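Methyl addition on the pyrimidinyl core: cytotoxicity outlook

The compounds below may be only part of what the source reports. "The series", "measured", "known", "first", "only" and "open" are said of these compounds alone.

Compound 1 `CC(C)=CCOc1cccc(Nc2nccs2)c1` and compound 2 `CC(C)=CCOc1cc(Nc2nccs2)ccc1C` share one core. In a functional assay on MT2 cells (Homo sapiens) for cytotoxicity, read by MTT assay (a lower number here means that less compound is tolerated, a higher number that more compound is tolerated), compound 1 gives 23000 nM and compound 2 gives 17000 nM, so the change methyl in place of hydrogen on an aromatic carbon made a step of a 1.4-fold lower number from compound 1 to compound 2 (0.13 log units; within the scatter). Compound 3 `CC(C)=CCOc1cccc(Nc2ncccn2)c1` carries the other core; the difference is pyrimidin-2-yl in place of 1,3-thiazol-2-yl on a nitrogen on an aromatic ring, and the step in this assay is an at least 4.3-fold higher number from compound 1 to compound 3 (0.63 log units; beyond the scatter). For compound 3 the value > 100000 nM is a limit of the assay, (the limit of > 100000 nM in this assay, at which 1 of the 3 values shown sits). Compound 4 `CC(C)=CCOc1cc(Nc2ncccn2)ccc1C` is not yet measured. It differs from compound 3 by methyl in place of hydrogen on an aromatic carbon, the same kind of change as from compound 1 to compound 2, though there the methyl sits para to a (1,3-thiazol-2-yl)amino group (6 heavy atoms) and here para to a group of 7 heavy atoms. Compound 4 is expected to show a step that the limit leaves unreadable from compound 3 to compound 4 in this assay. That expectation rests on compound 1 and compound 2, whose step a 1.4-fold lower number from compound 1 to compound 2 (0.13 log units; within the scatter) lay within the scatter. Compound 4 is therefore estimated at 120000 nM in this assay, between 50000 nM and 300000 nM, most probably reported again only as a limit.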

Compound 4, half-maximal cytotoxic concentration: 78000 nM
Compound 4: middle estimate off by 1.5-fold (0.19 log units), on the high side, and the stated range covers the measured number.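

In this assay, methyl in place of hydrogen on an aromatic carbon gives an at least 1.2-fold lower number from compound 3 to compound 4 (0.10 log units; that floor lies within the scatter), set here against the same change on the other core: the same change on two cores in this assay, a 1.4-fold lower number (0.13 log units; within the scatter) from compound 1 to compound 2 and an at least 1.2-fold lower number (0.10 log units; that floor lies within the scatter) from compound 3 to compound 4; the limit leaves it open whether they differ

Pyrimidin-2-yl in place of 1,3-thiazol-2-yl, now on the methyl-bearing compounds, gives a 4.6-fold higher number from compound 2 to compound 4 (0.66 log units; beyond the scatter), in the same direction as before: the same change on two cores in this assay, an at least 4.3-fold higher number (0.63 log units; beyond the scatter) from compound 1 to compound 3 and a 4.6-fold higher number (0.66 log units; beyond the scatter) from compound 2 to compound 4; the limit leaves it open whether they differ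

Compound 3 stands only as a limit of the assay, > 100000 nM, so nothing here fixes the size of the methyl step on its core or proves that this step carries over unchanged: the limit of > 100000 nM in this assay, at which 1 of the 4 values shown sits.

Going by these compounds, whether an ethyl, a methoxy or a chlorine on the same aromatic carbon would follow the methyl remains open. So does whether a shorter chain in place of the (3-methylbut-2-en-1-yl)oxy group would keep the gap between the two cores.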